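The source may report more compounds than this note shows. Statements on the series, on what has been measured and on what is new or still open speak of the compounds shown alone.

Measured compounds in a functional assay on Caco-2 cells (Homo sapiens) for cytotoxicity, read by MTT assay, with stated times of 6 h and 48 h; on this read-out higher numbers stand for weaker inhibition and lower numbers for stronger inhibition:
compound 1, `Cn1c(/C=C/C(=O)c2ccccc2O)cc(Br)c1Br` — 3160 nM
compound 2, `Cn1c(/C=C/C(=O)c2cc(O)ccc2O)cc(Br)c1Br` — >= 100000 nM
compound 3, `Cn1c(-c2cc(-c3ccccc3)no2)cc(Br)c1Br` — 16600 nM

Of the compounds shown here, three have been measured so far in this assay. Compound 1 gives 3160 nM. Compound 2 does not give a number: its value of >= 100000 nM is a limit of the assay, and it sits at the limit of >= 100000 nM in this assay, at which 1 of the 3 values shown sits. The change from compound 1 to compound 2 is hydroxy in place of hydrogen on an aromatic carbon, and it produced an at least 31-fold higher number from compound 1 to compound 2 (1.50 log units; beyond the scatter).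

Compound 3 is built on a different core; the difference between the core of compound 1 and the core of compound 3 is not broken down here. In this assay compound 3 gives 16600 nM, the highest number among the two measured numbers.

Compound 4, `Cn1c(-c2cc(-c3ccccc3O)no2)cc(Br)c1Br`, has not yet been measured in this assay. It differs from compound 3 by hydroxy in place of hydrogen on an aromatic carbon. Within the data shown here, this is the same kind of change as the one from compound 1 to compound 2, but not the same: there the entering group sat meta to a large group and para to a hydroxy group (1 heavy atom), whereas here it sits ortho to a large group. Because the earlier step gave an at least 31-fold higher number from compound 1 to compound 2 (1.50 log units; beyond the scatter), the expectation for compound 4 is a weaker value than compound 3, with a step estimated at a 3.0-fold higher number from compound 3 to compound 4 (0.48 log units; beyond the scatter). Since compound 3 already gives 16600 nM, the estimate for compound 4 is 50000 nM, expected to fall between 15000 nM and 100000 nM.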

Compound 4, half-maximal inhibitory concentration: >= 100000 nM
Compound 4: a limit, no number; the forecaster's own chance of this, stated with the estimate: 45%; at least 2.0-fold (0.30 log units) between middle value and limit.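

In this assay compound 4 gives >= 100000 nM, which is a limit of the assay and not a number. Hydroxy in place of hydrogen on an aromatic carbon gave an at least 6.0-fold higher number from compound 3 to compound 4 (0.77 log units; beyond the scatter), so on both cores the change moved the read-out in the same direction, towards weaker inhibition, and that direction carried over from the core of compound 1 to the core of compound 3 in these two pairs. This does not show that the size of the step carries over, nor can the core alone be singled out, since the hydroxy also enters at a different place in each pair, and the comparison of the two steps stays unresolved: the same change on two cores in this assay, an at least 31-fold higher number (1.50 log units; beyond the scatter) from compound 1 to compound 2 and an at least 6.0-fold higher number (0.77 log units; beyond the scatter) from compound 3 to compound 4; the limit leaves it open whether they differ.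

The compounds shown leave open whether a different group entering at the same place on the core of compound 3, such as methoxy, an amine or a carboxylic acid, would also weaken inhibition as hydroxy does. They also leave open how much weaker compound 2 and compound 4 really are, as neither gives a number and the upper end of the read-out is now reached twice: the limit of >= 100000 nM in this assay, at which 2 of the 4 values shown sit.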